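This account rests on a few compounds, and the source may have more. Where it says the series, first, only, none or still open, it means among the compounds named here.

In a functional assay on PC-3 cells (Homo sapiens) for cytotoxicity (on this read-out higher numbers stand for an effect only at larger amounts of compound and lower numbers for an effect already at smaller amounts), compound 1 `COC1=C(C)C(=O)/C(=C(O)/C=C/c2ccc(Br)cc2)C(=O)C1(C)C` gives 17.7 ug/mL as its read-out, and compound 2 `COC1=C(C)C(=O)/C(=C(O)/C=C/c2ccccc2C)C(=O)C1(C)C` gives 9 ug/mL as its read-out. Compound 3 `COC1=C(C)C(=O)/C(=C(O)/C=C/c2c(C)cc(C)cc2C)C(=O)C1(C)C` has only a limit, > 20 ug/mL, and not a number. Among the compounds with values here, the one step between two numbers is a 2.0-fold lower number from compound 1 to compound 2 (0.29 log units; within the scatter), on exchange of the aromatic group. Compound 2 therefore cannot be told apart from compound 1 on these data, and it has no third number to be ranked against.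

The change followed here puts the 1,3-thiazol-2-yl of compound 4 `COC1=C(C)C(=O)/C(=C(O)/C=C/c2nccs2)C(=O)C1(C)C` in place of the 2-methylphenyl of compound 2, on a double-bonded chain carbon bound to a double-bonded chain carbon (1,3-thiazol-2-yl in place of 2-methylphenyl on a double-bonded chain carbon bound to a double-bonded chain carbon). Within the data shown here, no measured compound carries a five-membered aromatic ring with hetero atoms at this place, so the guidance is indirect. It rests on compound 2, whose step a 2.0-fold lower number from compound 1 to compound 2 (0.29 log units; within the scatter) stayed within the scatter. No shift beyond the scatter is therefore expected in this assay, and the estimated change is a 1.3-fold higher number from compound 2 to compound 4 (0.12 log units; within the scatter) at this place. Compound 4 may also end at the limit of > 20 ug/mL in this assay, at which 1 of the 3 values shown sits, and then no number would be reported. For compound 4 the estimated value is 12 ug/mL, with an expected range from 5 ug/mL to 20 ug/mL in this assay.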

Compound 4, concentration for half-maximal effect: 10.8 ug/mL
Beside the measured number, compound 4's estimate is 1.1-fold (0.05 log units) above it; the range from low to high includes it.
By their numbers in this assay, from the lowest: compounds 2, 4 and 1 (each within the scatter of the next). At a limit, above all of these: compound 3.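

Within the data shown here, on a double-bonded chain carbon bound to a double-bonded chain carbon, the earlier compounds carried only six-membered aromatic rings of carbon, and compound 4 is the first here to carry a five-membered aromatic ring with 2 hetero atoms. In this assay this exchange gives a 1.2-fold higher number from compound 2 to compound 4 (0.08 log units; within the scatter) and a 1.6-fold lower number from compound 1 to compound 4 (0.21 log units; within the scatter) so the change of ring type, with 2 hydrogen-bond acceptors entering and fewer heavy atoms than in the 2-methylphenyl, moves the read-out beyond the scatter in neither comparison. Compound 3 remains the only compound shown with a limit and not a number: the limit of > 20 ug/mL in this assay, at which 1 of the 4 values shown sits.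

With all the numbers within the scatter of one another, the compounds shown give no order among these groups and no reason for the limit of compound 3. They also leave open whether an aminomethyl group, a carboxylic acid or a longer chain in place of the 1,3-thiazol-2-yl at this place, or a change elsewhere on the shared core, would shift the number in this assay beyond the scatter.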